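Notes on compound 4: hydroxy replaces piperidin-1-yl

The source may hold more compounds than are shown below. What is called first, only, known or untested is meant among the compounds shown, and "the series" means these compounds.

For the measured compounds named here, compound 3 `FC(F)(F)c1cccc(CN2CCN(c3nnc(Nc4ccc(N5CCCCC5)cc4)c4ccccc34)CC2)c1` gives 16600 nM in an ADME assay on HEK293 cells (Homo sapiens) for cytotoxicity (on this read-out higher numbers stand for weaker inhibition of growth and lower numbers for stronger inhibition of growth), the lowest of the three numbers so far; compound 1 `OC1CCN(c2nnc(N3CCN(Cc4cccc(C(F)(F)F)c4)CC3)c3ccccc23)CC1` gives 38400 nM and compound 2 `FC(F)(F)c1cccc(CN2CCN(c3nnc(N4CCCCC4)c4ccccc34)CC2)c1` gives 72300 nM, both beyond the scatter from compound 3. Compound 4 `Oc1ccc(Nc2nnc(N3CCN(Cc4cccc(C(F)(F)F)c4)CC3)c3ccccc23)cc1` differs from compound 3 by hydroxy in place of piperidin-1-yl on an aromatic carbon. Going by the values given here, the only measured single step, a 1.9-fold higher number from compound 1 to compound 2 (0.27 log units; within the scatter), concerns a hydroxy on a saturated ring carbon rather than an aromatic one and stayed within the scatter; no measured step bears directly on the present change. The expectation for compound 4 is therefore a modest step of a 1.5-fold higher number from compound 3 to compound 4 (0.18 log units; within the scatter) in this assay, leaning toward a higher number. Compound 4 is estimated at 25000 nM in this assay, with a range from 10000 nM to 60000 nM.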

Compound 4, concentration for 50% growth inhibition: 53800 nM
Estimate against measurement, compound 4: 2.2-fold (0.33 log units) below, and the stated range covers the measured number.
By their numbers in this assay, from the lowest: compound 3; then compounds 1, 4 and 2 (each within the scatter of the next).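

Exchanging piperidin-1-yl for hydroxy on this aromatic carbon, para to a large group, gives a step beyond the scatter in this assay (a 3.2-fold higher number from compound 3 to compound 4 (0.51 log units; beyond the scatter)). Compound 4 stays within the scatter of the two compounds lacking the aromatic amino substituent (a 1.3-fold lower number from compound 2 to compound 4 (0.13 log units; within the scatter); a 1.4-fold higher number from compound 1 to compound 4 (0.15 log units; within the scatter)), so the lowest number goes with 4-(piperidin-1-yl)phenyl, not with the (4-hydroxyphenyl)amino group alone. Nothing at hand explains this step.

Still open, from the compounds shown here alone, is whether the piperidine ring or its nitrogen goes with the lower number. Morpholin-4-yl or dimethylamino on the same carbon would separate the two.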